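This account rests on a few compounds, and the source may have more. Where it says the series, first, only, none or still open, it means among the compounds named here.

Among the measured compounds shown here, compound 1 `COc1ccc(CN(C(=O)C2CC2)c2cc(OC)c(OC)c(OC)c2)cc1O` is the more potent of the two measured members. In a functional assay on MGC-803 cells (Homo sapiens) for inhibition, read by MTT assay, with a stated time of 48 h (on this read-out lower numbers stand for stronger inhibition and higher numbers for weaker inhibition), compound 1 gives 59 nM, the lowest of the two numbers, while compound 2 `C/C=C/C(=O)N(Cc1cc(OC)c(OC)c(OC)c1)c1ccc(OC)c(O)c1` gives 6150 nM, a gap far beyond the scatter. Compound 3 `COc1ccc(CN(C(=O)CCCl)c2cc(OC)c(OC)c(OC)c2)cc1O` is not yet measured; it differs from compound 1 in one place: 2-chloroethyl in place of cyclopropyl on a carbonyl carbon. For the measured compounds named here, no measured pair shows this change, so the expected step is small, a modest loss at most, and the step from compound 1 to compound 3 is estimated as a 2.0-fold higher number from compound 1 to compound 3 (0.31 log units; beyond the scatter). Compound 3 is expected to give 120 nM, with a range from 30 nM to 500 nM.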

Compound 3, half-maximal inhibitory concentration: 140 nM
For compound 3 the middle estimate is 1.2-fold (0.07 log units) below the measured one; the range from low to high includes it.
By their numbers in this assay, from the lowest: compound 1; then compound 3; then compound 2.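

At this carbonyl carbon the cyclopropyl ring is not required for activity in this assay: the open 2-chloroethyl chain, with the same count of heavy atoms, gives a 2.4-fold higher number from compound 1 to compound 3 (0.38 log units; beyond the scatter) and is thus a modest loss. Among the compounds shown here, this is the first step read at one place, and it shows that the position tolerates a ring-to-chain change carrying chlorine. Nothing measured here gives a reason for the step.

A propyl group at this carbonyl carbon would separate loss of the ring from entry of the chlorine. On these data alone, how a longer chain or an amine reads here also stays open.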